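Chloro Added to the Phenyl Ring of Compound 2

The source may report more compounds than this note shows. Statements on the series, on what has been measured and on what is new or still open speak of the compounds shown alone.

Measured so far:
compound 1 `Cn1c(CN2CCN(c3ccccc3C(F)(F)F)CC2)nc2ccccc21` – 84%
compound 2 `Cn1c(CN2CCC(c3ccccc3)CC2)nc2ccccc21` – 89%

In an assay on CHO cells with metabotropic glutamate receptor 2 (Homo sapiens) as the target, read by FLIPR (on this read-out lower numbers stand for smaller maximal responses and higher numbers for larger maximal responses), compound 2 gives 89% and compound 1 gives 84%. Compound 2 carries the upper of the two numbers, but its distance to compound 1 is within the usual scatter, so the two cannot be told apart on this read-out. Within the data shown here, no one-point step between measured compounds is available to guide the next change.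

Compound 3 `Cn1c(CN2CCC(c3ccc(Cl)cc3)CC2)nc2ccccc21` differs from compound 2 by chloro in place of hydrogen on an aromatic carbon. Nothing in the data shows how such a change behaves here; the most defensible expectation is therefore a small step, in either direction, not beyond the scatter. Compound 3 is expected to give a maximal response of about 87%, between 72% and 100%. That expectation means an estimated step of a number 2 percentage points lower from compound 2 to compound 3 (within the scatter).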

Compound 3, largest response reached (Emax), in percent of the reference or control that the assay uses: 91%
For compound 3 the middle estimate is 4 percentage points below the measured one; low and high end bracket the measured number.
By their numbers in this assay, from the lowest: compounds 1, 2 and 3 (each within the scatter of the next).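

Going from phenyl to 4-chlorophenyl gives a number 2 percentage points higher from compound 2 to compound 3 (within the scatter) in this assay. Among these compounds, this is the first comparison here between two compounds that differ in one place only, and it shows that with chloro on this aromatic carbon, para to a large group, the maximal response cannot be told apart from that with hydrogen. Nothing measured here speaks to the reason for this outcome.

Open, from the compounds shown here alone, is whether a larger or very different group in the same place, such as an amine, a carboxylic acid or a longer chain, would also leave the maximal response unchanged. The compounds shown also leave open whether chloro would behave the same way on another aromatic carbon of this ring, or on the phenyl ring of compound 1.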